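The compounds below may be only part of what the source reports. "The series", "measured", "known", "first", "only" and "open" are said of these compounds alone.

Measured compounds:
- Compound 1, `COc1cc([C@@H](O)[C@@H](C)Oc2ccc([C@@H]3O[C@H](c4ccc(O)c(OC)c4)[C@H](C)[C@H]3C)cc2OC)ccc1O`: in an ADME assay on P3HR-1 cells (Homo sapiens) for cytotoxicity, read by microscopy and trypan blue exclusion, with a stated time of 2 days (on this read-out lower numbers stand for higher toxicity in this test and higher numbers for lower toxicity in this test), compound 1 gives 23200 nM.
- Compound 2, `COc1ccc([C@H]2O[C@@H](c3cc(OC)c(O)c(OC)c3)[C@H](C)[C@@H]2C)cc1OC`: in this assay compound 2 gives 101000 nM.

Compound 2 stands at the highest of the two numbers, that is, it is the less toxic of the pair, and compound 1 sits below it by a gap that lies beyond the usual scatter. Going by the values given here, the two measured compounds differ from each other in several places at once, so no single step between them can be read, and nothing more than their two values can be said of that pair.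

Compound 3, `COc1ccc([C@H]2O[C@@H](c3cc(OC)c(OC)c(OC)c3)[C@H](C)[C@@H]2C)cc1OC`, differs from compound 2 in one place only: methyl in place of hydrogen on an oxygen on an aromatic ring. Among the compounds with values here, no measured pair shows what this kind of change does in this assay, so the expectation rests on compound 2 alone. Little movement beyond the scatter is expected, with a slight lean toward a lower number, an expected step of a 1.3-fold lower number from compound 2 to compound 3 (0.13 log units; within the scatter). For compound 3 the estimate is 75000 nM, within a range from 30000 nM to 200000 nM.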

Compound 3, half-maximal cytotoxic concentration: 172000 nM
For compound 3 the middle estimate is 2.3-fold (0.36 log units) below the measured one, and the stated range covers the measured number.
By their numbers in this assay, from the lowest: compound 1; then compounds 2 and 3 (each within the scatter of the next).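

In this assay, going by these compounds alone, turning hydroxy into methoxy on this aromatic ring gives a 1.7-fold higher number from compound 2 to compound 3 (0.23 log units; within the scatter), the first change in a single place that can be read. For this pair, then, the hydrogen on that oxygen can be replaced by methyl without moving the number beyond the normal spread of repeat measurements, so the hydroxy and methoxy compounds cannot be told apart in this test. No separate measurement is available to explain this result.

On these data alone, whether a longer chain such as ethyl on this oxygen, or an amine in place of the hydroxy group, would also stay within that spread remains open, as does what the same change would do elsewhere on the shared core. As far as these compounds go, compound 1 differs from compound 2 and compound 3 in several places at once, so its steps to them cannot be read, and which of its differences goes with its number remains unknown.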